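Amino for Chloro on a Core That Shows No Toxicity

The source may report more compounds than this note shows. Statements on the series, on what has been measured and on what is new or still open speak of the compounds shown alone.

Compound 1 `Nc1nn(C(=O)Nc2ccc(Cc3ccccc3)cc2)c2ccccc12`: in a functional assay on NCI-H322M cells (Homo sapiens) for antiproliferative activity, read by sulforhodamine B assay, with a stated time of 48 h (on this read-out lower numbers stand for higher toxicity in this test and higher numbers for lower toxicity in this test), compound 1 gives only a limit, > 100000 nM.
Compound 2 `Nc1nn(C(=O)Nc2ccc(Cc3ccccc3)cc2)c2ccc(Cl)cc12`: in this assay compound 2 gives only a limit, > 100000 nM.

Compound 2 thus stands at a limit of this assay rather than at a number, as does the other value shown: the limit of > 100000 nM in this assay, at which 2 of the 2 values shown sit. Among the compounds with values here, the single measured step, a step that the two limits leave unreadable from compound 1 to compound 2, cannot be sized because both ends sit at that limit.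

Compound 3 `Nc1ccc2c(c1)c(N)nn2C(=O)Nc1ccc(Cc2ccccc2)cc1` differs from compound 2 by amino in place of chloro on an aromatic carbon. No readable step bears on this change, so no direction can be drawn, and a result that again reaches only the limit is the plain expectation. Compound 3 is therefore estimated at 150000 nM, between 40000 nM and 600000 nM. This estimate means an expected step that the limit leaves unreadable from compound 2 to compound 3, nothing beyond the scatter, and most likely a limit once more.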

Compound 3, concentration lethal to 50% of the cells: 58300 nM
The estimate for compound 3 lay 2.6-fold (0.41 log units) above the measured number, and the stated range covers the measured number.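

Among the compounds shown, only the amino group at this position brings the core to an actual number in this assay rather than a limit. The change from chloro reads as an at least 1.7-fold lower number from compound 2 to compound 3 (0.23 log units; that floor lies within the scatter), and the change from hydrogen reads as an at least 1.7-fold lower number from compound 1 to compound 3 (0.23 log units; that floor lies within the scatter). Both are only floors, and the full size of either step stays unknown because compound 1 and compound 2 end at a limit: the limit of > 100000 nM in this assay, at which 2 of the 3 values shown sit.

On these data alone, it remains open whether a hydroxyl, a methoxy or a dimethylamino group at this place would give a number too. As far as these compounds go, it is also open whether an acetamide would keep the number that the amino group gives.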